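Tetrazole against carboxy on two related cores

This account rests on a few compounds, and the source may have more. Where it says the series, first, only, none or still open, it means among the compounds named here.

Measured so far in a functional assay on the whole organism (strain Sprague-Dawley) for inhibition, with Rattus norvegicus as the target; a lower number here means that less compound is needed, a higher number that more compound is needed for the effect:
compound 1, `COc1ccc2cc(-c3nn[nH]n3)cnc2c1`, gives 5 mg/kg
compound 2, `FC(F)(F)c1cccc2cc(-c3nn[nH]n3)cnc12`, gives < 25 mg/kg
compound 3, `COc1ccc2cc(C(=O)O)cnc2c1`, gives > 25 mg/kg

For the measured compounds named here, compound 1 is the only member with a plain number. For compound 2 the value is a limit, (the limit of < 25 mg/kg in this assay, at which 1 of the 3 values shown sits). For compound 3 the value is likewise a limit, (the limit of > 25 mg/kg in this assay, at which 1 of the 3 values shown sits).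

Going by the values given here, the one counted change is carboxy in place of 2H-tetrazol-5-yl on an aromatic carbon. It turns compound 1 into compound 3 and gives an at least 5.0-fold higher number from compound 1 to compound 3 (0.69 log units; beyond the scatter). The cores of compound 1 and compound 2 differ in more than one place, and that difference is not broken down here. The unmeasured compound 4, `O=C(O)c1cnc2c(C(F)(F)F)cccc2c1`, stands to compound 2 as compound 3 stands to compound 1: the change is carboxy in place of 2H-tetrazol-5-yl on an aromatic carbon, with the same surroundings at the place of exchange, so it is the same change.

If the exchange behaves on the core of compound 2 as it did on the core of compound 1, compound 4 should need more than compound 2. The step from compound 2 to compound 4 in this assay is expected to be an at least 1.6-fold higher number from compound 2 to compound 4 (0.20 log units; that floor lies within the scatter), resting on the size of an at least 5.0-fold higher number from compound 1 to compound 3 (0.69 log units; beyond the scatter). Since compound 2 is itself only known as a limit, the expectation for compound 4 is wide, and it is estimated at 40 mg/kg, between 15 mg/kg and 120 mg/kg, most likely reported only as a limit.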

Compound 4, minimum effective dose: 50 mg/kg
Compound 4: the middle estimate sits 1.3-fold (0.10 log units) below what was measured; low and high end bracket the measured number.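

In this assay, the exchange of 2H-tetrazol-5-yl for carboxy on an aromatic carbon can now be read on a second core, as an at least 2.0-fold higher number from compound 2 to compound 4 (0.30 log units; that floor lies within the scatter). Both steps point to a higher number with carboxy, which shows that the direction seen on the core of compound 1 is not contradicted on the second core, but it does not show that the size of the change carries over: the same change on two cores in this assay, an at least 5.0-fold higher number (0.69 log units; beyond the scatter) from compound 1 to compound 3 and an at least 2.0-fold higher number (0.30 log units; that floor lies within the scatter) from compound 2 to compound 4; the limit leaves it open whether they differ The value of compound 2 is a limit, so the new step gives only a floor and no exact size: the limit of < 25 mg/kg in this assay, at which 1 of the 4 values shown sits.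

The two cores differ in more than one place, so the compounds shown leave open which of those differences, if any, bears on the size of the exchange, and a pair with a plain number on both sides would be needed to compare sizes on the two cores. Also open, on these data alone, is how the exchange behaves on any further core in this assay, and what another group at the same place, such as an amide, a sulfonamide or a nitrile, would give.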